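The source may hold more compounds than are shown below. What is called first, only, known or untested is meant among the compounds shown, and "the series" means these compounds.

Compound 1 `Oc1n[nH]c(CN[C@H](COCc2cc(C(F)(F)F)cc(C(F)(F)F)c2)c2ccccc2)n1` gives 2.4 nM in an assay on CHO cells for displacement of a labelled ligand from Substance-P receptor (Homo sapiens); a lower number here means a stronger inhibitor, a higher number a weaker inhibitor. Compound 2 `FC(F)(F)c1cc(COC[C@@H](NCc2nn[nH]n2)c2ccccc2)cc(C(F)(F)F)c1` gives 23 nM in this assay, and compound 3 `Cn1nnnc1CN[C@H](COCc1cc(C(F)(F)F)cc(C(F)(F)F)c1)c1ccccc1` gives 10 nM. Among these three, compound 3 sits second highest: a 2.3-fold lower number from compound 2 to compound 3 (0.36 log units; beyond the scatter), while a 4.2-fold higher number from compound 1 to compound 3 (0.62 log units; beyond the scatter).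

Compound 4 `CCCN(Cc1n[nH]c(O)n1)[C@H](COCc1cc(C(F)(F)F)cc(C(F)(F)F)c1)c1ccccc1` has not yet been measured. It differs from compound 3 in one place: ((5-hydroxy-1H-1,2,4-triazol-3-yl)methyl)(propyl)amino in place of ((1-methyl-1H-tetrazol-5-yl)methyl)amino on a saturated chain carbon bound to an aromatic carbon and a saturated chain carbon. This change brings back the hydroxytriazolyl ring of compound 1 and, at the same time, puts a propyl group on the amine nitrogen. Only the ring part of the change has a measured counterpart, the step from compound 1 to compound 3, where a 4.2-fold higher number from compound 1 to compound 3 (0.62 log units; beyond the scatter); reversing it should bring a step of similar size in the other direction. Going by the values given here, no measured pair shows what the propyl group on the nitrogen does, so that part remains open. On balance compound 4 is expected to sit below compound 3 in this assay, with a 2.5-fold lower number from compound 3 to compound 4 (0.40 log units; beyond the scatter). The estimate for compound 4 is therefore 4 nM, with a range from 1.2 nM to 20 nM.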

Compound 4, half-maximal inhibitory concentration: 2 nM
The estimate for compound 4 lay 2.0-fold (0.30 log units) above the measured number; measured number inside the range.
By their numbers in this assay, from the lowest: compounds 4 and 1 (each within the scatter of the next); then compound 3; then compound 2.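

The open question was the propyl group on the amine nitrogen, and compound 1 now answers it for the hydroxytriazolyl ring: a 1.2-fold lower number from compound 1 to compound 4 (0.08 log units; within the scatter) shows that adding this group leaves the number unchanged within the scatter. Compound 4 also keeps the advantage of that ring over both tetrazole compounds, with a 5.0-fold lower number from compound 3 to compound 4 (0.70 log units; beyond the scatter) and a 12-fold lower number from compound 2 to compound 4 (1.06 log units; beyond the scatter) as the two steps. This position on the amine nitrogen can therefore carry a propyl group without losing inhibition, at least with this ring attached.

As far as these compounds go, whether a methyl group, a longer chain such as butyl, or a propyl group on the nitrogen of the tetrazole compounds would behave the same way remains open. Nothing available explains why the propyl group leaves the number in place.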